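Aryl swap on the cyclopropane carbon: pyridin-2-yl to furan-3-yl

The compounds below may be only part of what the source reports. "The series", "measured", "known", "first", "only" and "open" are said of these compounds alone.

The series shares one core, varied at the aryl group on a saturated ring carbon. Compound 1 `CC[C@H](C)[C@H](N)CN(C(=O)[C@@H]1C[C@H]1c1cccc(C#N)c1)c1ccc(-c2ccccc2)cc1` gives 1600 nM in a functional assay for agonist activity at G protein-coupled receptor 88 (Homo sapiens), read by HTRF and cAMP accumulation; a lower number here means that less compound is needed, a higher number that more compound is needed for the effect. Compound 2 `CC[C@H](C)[C@H](N)CN(C(=O)[C@@H]1C[C@H]1c1c(F)cccc1F)c1ccc(-c2ccccc2)cc1` gives 11000 nM. Compound 3 `CC[C@H](C)[C@H](N)CN(C(=O)[C@@H]1C[C@H]1c1ccccn1)c1ccc(-c2ccccc2)cc1` gives 130 nM, the lowest of the three numbers; its steps to the other two are both beyond the scatter, a 12-fold lower number from compound 1 to compound 3 (1.09 log units; beyond the scatter) and an 85-fold lower number from compound 2 to compound 3 (1.93 log units; beyond the scatter), while the remaining step is a 6.9-fold higher number from compound 1 to compound 2 (0.84 log units; beyond the scatter).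

Compound 4 `CC[C@H](C)[C@H](N)CN(C(=O)[C@@H]1C[C@H]1c1ccoc1)c1ccc(-c2ccccc2)cc1` is not yet measured. The change is furan-3-yl in place of pyridin-2-yl on a saturated ring carbon. Within the data shown here, no measured step covers this exact pair; the three steps that do exist all exchange the aryl group at this same position and range from modest to large, with pyridin-2-yl giving the lowest number each time. Leaving pyridin-2-yl is therefore expected to raise the number, and the expected step is a 6.9-fold higher number from compound 3 to compound 4 (0.84 log units; beyond the scatter), smaller than the step from compound 2 to compound 3 but clearly beyond the scatter. Compound 4 is estimated at 900 nM, within 250 nM to 4000 nM.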

Compound 4, half-maximal effective concentration: 580 nM
For compound 4 the middle estimate is 1.6-fold (0.19 log units) above the measured one; the measured number falls inside the stated range.
By their numbers in this assay, from the lowest: compound 3; then compound 4; then compound 1; then compound 2.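

With furan-3-yl on the saturated ring carbon, pyridin-2-yl keeps the lowest number in this assay (a 4.5-fold higher number from compound 3 to compound 4 (0.65 log units; beyond the scatter)), so a second unsubstituted ring with one hetero atom does not match it. Even so, furan-3-yl gives a lower number than either substituted phenyl group (a 2.8-fold lower number from compound 1 to compound 4 (0.44 log units; beyond the scatter); a 19-fold lower number from compound 2 to compound 4 (1.28 log units; beyond the scatter)), and among these four compounds both rings with a hetero atom lie below both phenyl groups, with no compound against that order. Nothing available explains the order at this position.

This change alters ring size and the hetero atom together, so the two contributions cannot be separated here. Open, as far as these compounds go, is how pyridin-3-yl, furan-2-yl or unsubstituted phenyl would read at this position, which would test the place of the hetero atom and the need for one.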